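The source may hold more compounds than are shown below. What is called first, only, known or untested is meant among the compounds shown, and "the series" means these compounds.

Measured so far in a functional assay on PANC-1 cells (Homo sapiens) for inhibition, read by MTT assay, with a stated time of 24 h, tested at 10 uM; a lower number here means less inhibition, a higher number more inhibition at the concentration tested (going by the name of the read-out):
compound 1 `CC(C)=CCC1Cc2c(OCCCNC(=O)c3ccco3)cc(=O)n(CCCO)c2CC1(C)C` gives 4.3%;
compound 2 `CC(C)=CCC1Cc2c(OCCCNC(=O)c3cccs3)cc(=O)n(CCCO)c2CC1(C)C` gives 5.6%;
compound 3 `CC(C)=CCC/C(C)=C/CC1Cc2c(OCCCNC(=O)c3ccco3)cc(=O)n(CCCO)c2CC1(C)C` gives 2.8%.

All three numbers are small and lie within the usual scatter of one another, so none of them can be called stronger or weaker than another. Compound 4 `CC(C)=CCC/C(C)=C/CC1Cc2c(OCCCNC(=O)c3cccs3)cc(=O)n(CCCO)c2CC1(C)C` has not yet been measured. It stands to compound 3 exactly as compound 2 stands to compound 1: the difference is thiophen-2-yl in place of furan-2-yl on a carbonyl carbon, and this same change thiophen-2-yl in place of furan-2-yl on a carbonyl carbon appears twice among these four compounds, at the same place each time. Where it has already been measured, it made a number 1.3 percentage points higher from compound 1 to compound 2 (within the scatter). The two cores on which it sits differ by 3-methylbut-2-en-1-yl in place of hydrogen on a saturated chain carbon bound to a double-bonded chain carbon, a change that made a number 1.5 percentage points lower from compound 1 to compound 3 (within the scatter).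

For compound 4 in this assay the step is expected to be a number 1.3 percentage points higher from compound 3 to compound 4 (within the scatter), beside the earlier one, because a number 1.3 percentage points higher from compound 1 to compound 2 (within the scatter) was small and the change of core also moved the number only a little. Compound 4 is therefore estimated to give about 4.1%, most likely between 0% and 12%.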

Compound 4, a percentage reported as inhibition, at one concentration (the size of the read-out at that concentration, not a potency): 11.5%
For compound 4 the middle estimate is 7.4 percentage points below the measured one; the range from low to high includes it.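

In this assay, thiophen-2-yl in place of furan-2-yl on the longer-chain core gives a number 8.7 percentage points higher from compound 3 to compound 4 (within the scatter), and set beside the earlier step, this change carries from one core to the other as far as these measurements can tell: the same change on two cores in this assay, a number 1.3 percentage points higher (within the scatter) from compound 1 to compound 2 and a number 8.7 percentage points higher (within the scatter) from compound 3 to compound 4, 7.4 percentage points apart, within the scatter of two such steps. The chain change, 3-methylbut-2-en-1-yl in place of hydrogen, gives a number 5.9 percentage points higher from compound 2 to compound 4 (within the scatter) on the thiophen-2-yl compounds, and it reads the same way: the same change on two cores in this assay, a number 1.5 percentage points lower (within the scatter) from compound 1 to compound 3 and a number 5.9 percentage points higher (within the scatter) from compound 2 to compound 4, 7.4 percentage points apart, within the scatter of two such steps. Neither step lies beyond the scatter, so this agreement does not show that either change has a real effect, that the two changes add up simply, or that the core has no influence on them.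

The compounds shown leave open whether a different ring on the carbonyl carbon, such as phenyl or pyridine, would give a number clearly beyond the scatter. They also leave open what an amine or a carboxylic acid in place of the hydroxyl group would do.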